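Swapping 3-chlorophenyl for 2,3-dimethylphenyl: a small step expected

The source may report more compounds than this note shows. Statements on the series, on what has been measured and on what is new or still open speak of the compounds shown alone.

Compound 1 `COc1cc(-n2cnc3ccc(-c4ccc([N+](=O)[O-])cc4)cc32)cc(OC)c1OC`, compound 2 `COc1cc(-n2cnc3ccc(-c4ccc(C(F)(F)F)cc4)cc32)cc(OC)c1OC` and compound 3 `COc1cc(-n2cnc3ccc(-c4cccc(Cl)c4)cc32)cc(OC)c1OC` share one core and differ in the aromatic group attached to it. In a functional assay on A549 cells (Homo sapiens) for antiproliferative activity, read by MTT assay, with a stated time of 72 h (on this read-out higher numbers stand for weaker inhibition and lower numbers for stronger inhibition), compound 1 gives 8940 nM, compound 2 gives 3390 nM and compound 3 gives 7050 nM. Compound 3 thus stands with compound 1 at the weaker end of a narrow range. In compound 4 `COc1cc(-n2cnc3ccc(-c4cccc(C)c4C)cc32)cc(OC)c1OC`, 2,3-dimethylphenyl takes the place of 3-chlorophenyl on an aromatic carbon (2,3-dimethylphenyl in place of 3-chlorophenyl on an aromatic carbon). Earlier swaps of this group moved the number little: a 1.3-fold lower number from compound 1 to compound 3 (0.10 log units; within the scatter), a 2.6-fold lower number from compound 1 to compound 2 (0.42 log units; beyond the scatter) and a 2.1-fold higher number from compound 2 to compound 3 (0.32 log units; beyond the scatter). No step beyond the scatter is therefore expected in this assay. The estimated step is a 1.2-fold lower number from compound 3 to compound 4 (0.07 log units; within the scatter). For compound 4 the expected value is 6000 nM, with an estimated range of 2500 nM to 14000 nM.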

Compound 4, half-maximal inhibitory concentration: 9250 nM
Compound 4: middle estimate off by 1.5-fold (0.19 log units), on the low side; the measured number falls inside the stated range.
By their numbers in this assay, from the lowest: compound 2; then compounds 3, 1 and 4 (each within the scatter of the next).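

In this assay, 2,3-dimethylphenyl in place of 3-chlorophenyl gives a 1.3-fold higher number from compound 3 to compound 4 (0.12 log units; within the scatter), and in place of 4-nitrophenyl it gives a 1.0-fold higher number from compound 1 to compound 4 (0.01 log units; within the scatter), so a phenyl carrying two methyl groups and no chlorine or nitro group sits level with both. The 4-(trifluoromethyl)phenyl group still stands apart, with a 2.7-fold higher number from compound 2 to compound 4 (0.44 log units; beyond the scatter). No measurement at hand explains this. Going by these compounds, whether an amine or a carboxylic acid on this phenyl would move the number further remains open. So does whether a lone methyl group would behave like the pair.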